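The compounds below may be only part of what the source reports. "The series", "measured", "known", "first", "only" and "open" are said of these compounds alone.

Measured compounds in the series:

compound 1 `CCNS(=O)(=O)c1cccc(-c2ccc(OCC)cc2)c1`; in an assay on COS-7 cells for inhibition of patatin-like phospholipase domain-containing protein 2 (Mus musculus) (on this read-out higher numbers stand for weaker inhibition and lower numbers for stronger inhibition), compound 1 gives 200000 nM.
compound 2 `CCOc1ccc(-c2cccc(C(=O)O)c2)cc1`; in this assay compound 2 gives > 200000 nM, which is a limit of the assay and not a number.
compound 3 `CCOc1ccc(-c2cccc(C(=O)NC)c2)cc1`; in this assay compound 3 gives > 200000 nM, again a limit of the assay and not a number.

Compound 3 therefore has no readable position: the step of a number no lower from compound 1 to compound 3 (the limit leaves the size open) is open in size, and the step that the two limits leave unreadable from compound 2 to compound 3 cannot be read at all.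

Compound 4 `CCOc1ccc(-c2cccc([N+](=O)[O-])c2)cc1` differs from compound 3 by nitro in place of methylcarbamoyl on an aromatic carbon. Going by the values given here, the steps that bear on this change are the other exchanges at the same aromatic carbon: a number no lower from compound 1 to compound 2 (the limit leaves the size open), a number no lower from compound 1 to compound 3 (the limit leaves the size open) and a step that the two limits leave unreadable from compound 2 to compound 3. None of them has a readable size, because the limit of > 200000 nM in this assay, at which 2 of the 3 values shown sit, keeps two of the three values from being numbers. There is thus no measured basis for a step beyond the scatter in either direction. Compound 4 is expected to sit near the same limit, with a number no higher from compound 3 to compound 4 (the limit leaves the size open) as the estimated step. The estimate for compound 4 in this assay is 200000 nM, within 60000 nM to 400000 nM.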

Compound 4, half-maximal inhibitory concentration: > 200000 nM
Compound 4: no number, only a limit (the forecaster's own chance of this, stated with the estimate: 75%); the middle value sits exactly at the limit.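

In this assay compound 4 gives > 200000 nM, which is a limit of the assay and not a number. Nitro in place of ethylsulfamoyl gives a number no lower from compound 1 to compound 4 (the limit leaves the size open). Nitro carries no hydrogen-bond donor, unlike the methylcarbamoyl it replaces, and this exchange at the aromatic carbon still yields no number, so carboxy, methylcarbamoyl and nitro all end at a limit here. The new steps from compound 1, compound 2 and compound 3 to compound 4 cannot be read in size, because the comparison runs into this limit: the limit of > 200000 nM in this assay, at which 3 of the 4 values shown sit.

Going by these compounds alone, compound 1 remains the only compound with a number, at 200000 nM. From the compounds shown here alone, whether that number belongs to the sulfonyl part or to the ethyl chain stays open, and a methylsulfamoyl, a propylsulfamoyl or an amine at this carbon would bear on that.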